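Aryl swap on the shared core: compound 1 to compound 3

The source may hold more compounds than are shown below. What is called first, only, known or untested is meant among the compounds shown, and "the series" means these compounds.

Among the measured compounds shown here, in a functional assay on SW1573 cells (Homo sapiens) for antiproliferative activity, read by sulforhodamine B assay, with a stated time of 48 h (a higher number here means a weaker inhibitor of growth, a lower number a stronger inhibitor of growth), compound 1 `COc1cc(-c2nc(CO[C@@H]3O[C@H](CSc4ncn[nH]4)[C@H]4OC5(CCCC5)O[C@@H]34)no2)cc(OC)c1OC` gives 36000 nM, the higher of the two numbers so far. For the measured compounds named here, compound 2 `Nc1nnc(SC[C@H]2O[C@@H](OCc3noc(-c4ccc([N+](=O)[O-])cc4)n3)[C@@H]3OC4(CCCC4)O[C@@H]32)s1` gives 16000 nM in this assay, a lower number by a gap beyond the scatter, but compound 2 differs from compound 1 in two places, so no single step is drawn from it. Compound 3 `O=[N+]([O-])c1ccc(-c2nc(CO[C@@H]3O[C@H](CSc4ncn[nH]4)[C@H]4OC5(CCCC5)O[C@@H]34)no2)cc1` differs from compound 1 by 4-nitrophenyl in place of 3,4,5-trimethoxyphenyl on an aromatic carbon. Compound 3 is expected to show a modest step downward a 1.8-fold lower number from compound 1 to compound 3 (0.26 log units; within the scatter) because compound 2 carries the same 4-nitrophenyl and gives 16000 nM. The estimate for compound 3 is 20000 nM, within 7000 nM to 60000 nM.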

Compound 3, concentration for 50% growth inhibition: 15000 nM
Compound 3: middle estimate off by 1.3-fold (0.12 log units), on the high side; the range from low to high includes it.
By their numbers in this assay, from the lowest: compounds 3 and 2 (each within the scatter of the next); then compound 1.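

In this assay the aryl position now has a readable step, with 4-nitrophenyl in place of 3,4,5-trimethoxyphenyl giving a 2.4-fold lower number from compound 1 to compound 3 (0.38 log units; beyond the scatter) on the shared core. With 4-nitrophenyl held fixed, 1H-1,2,4-triazol-5-yl in place of 5-amino-1,3,4-thiadiazol-2-yl on the sulfur gives a 1.1-fold lower number from compound 2 to compound 3 (0.03 log units; within the scatter) and so shows no readable difference. No available data explain either step.

Open, from the compounds shown here alone, is how a plain phenyl, or a phenyl carrying an amine or a carboxylic acid, would compare at this position. Also open, going by these compounds, is whether the 3,4,5-trimethoxyphenyl result holds with 5-amino-1,3,4-thiadiazol-2-yl on the sulfur.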